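The compounds below may be only part of what the source reports. "The series", "measured", "known", "first", "only" and "open" are said of these compounds alone.

Working notes on the series.

Of the compounds shown here, three of a shared core have been measured in an assay for inhibition of Polyunsaturated fatty acid 5-lipoxygenase (Homo sapiens), read by HPLC, with a stated time of 10 min; a higher number here means a weaker inhibitor, a lower number a stronger inhibitor. Compound 1 `CCOC(=O)c1c(CSc2ccccc2OC)n(C)c2ccc(O)cc12` gives 2900 nM and stands highest of the three numbers. Compound 2 `CCOC(=O)c1c(CSc2ccc(OC)cc2)n(C)c2ccc(O)cc12` gives 2300 nM; the step of a 1.3-fold lower number from compound 1 to compound 2 (0.10 log units; within the scatter) lies within the scatter, so no order between compounds 1 and 2 is claimed. Compound 3 `CCOC(=O)c1c(CSc2ccc(OC(F)(F)F)cc2)n(C)c2ccc(O)cc12` gives 900 nM; the step of a 2.6-fold lower number from compound 2 to compound 3 (0.41 log units; beyond the scatter) is modest but beyond the scatter. Among the compounds with values here, compound 1 to compound 3 shows the two values as they stand, with no single-place step recorded.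

The next compound, compound 4 `CCOC(=O)c1c(CSc2ccccc2C(F)(F)F)n(C)c2ccc(O)cc12`, differs from compound 1 in one place: trifluoromethyl in place of methoxy on an aromatic carbon. The change sits on an aromatic carbon of a six-membered aromatic ring of carbon only, ortho to a large group.

Bearing on this step: the one measured change that brings in trifluoromethyl, from compound 2 to compound 3, lowered the number by a 2.6-fold lower number from compound 2 to compound 3 (0.41 log units; beyond the scatter). The change here removes the oxygen as well, so the measured step is only a partial guide. The step from compound 1 to compound 4 is therefore expected to lower the number by a 2.4-fold lower number from compound 1 to compound 4 (0.38 log units; beyond the scatter), in the same direction as compound 3 against compound 2. Compound 4 is estimated at 1200 nM in this assay, with a range from 500 nM to 3000 nM.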

Compound 4, half-maximal inhibitory concentration: 800 nM
The estimate for compound 4 lay 1.5-fold (0.18 log units) above the measured number, and the stated range covers the measured number.
By their numbers in this assay, from the lowest: compounds 4 and 3 (each within the scatter of the next); then compounds 2 and 1 (each within the scatter of the next).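

The step from methoxy to trifluoromethyl on an aromatic carbon, ortho to a large group, gives in this assay a 3.6-fold lower number from compound 1 to compound 4 (0.56 log units; beyond the scatter), a modest gain. Within the data shown here, earlier, this place carried only methoxy, and the one trifluoromethyl step was made on an oxygen, so this is the first reading of a replacement that removes the oxygen and its hydrogen-bond acceptor from the aromatic carbon; the number still falls, so at this place that acceptor is not needed to keep the number low in this set. Nothing measured here accounts for the size or direction of the step.

One step cannot separate the loss of the oxygen from the arrival of the three fluorines, and a methyl or a trifluoromethoxy group at this same aromatic carbon would be needed to pull those two apart. Going by these compounds, it also remains open whether a chlorine atom, a nitrile or a longer chain such as ethyl at this place would keep the number as low as trifluoromethyl does.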